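This account rests on a few compounds, and the source may have more. Where it says the series, first, only, none or still open, it means among the compounds named here.

Measured so far in a physicochemical assay for lipophilicity, measured as octanol-water partition, at pH 7.4; on this read-out higher numbers stand for higher lipophilicity and lower numbers for lower lipophilicity:

compound 1 `Cc1ccc2[nH]c(C(=O)N[C@H]3CCN(S(=O)(=O)c4ccccc4)C[C@@H]3C(=O)NCCN(C)C)cc2c1` gives 2.2
compound 2 `Cc1ccc2[nH]c(C(=O)N[C@H]3CCN(S(=O)(=O)C4CC4)C[C@@H]3C(=O)NCCN(C)C)cc2c1` gives 1
compound 3 `Cc1ccc2[nH]c(C(=O)N[C@H]3CCN(S(=O)(=O)N4CCCCC4)C[C@@H]3C(=O)NCCN(C)C)cc2c1` gives 2.3

Compound 3 and compound 1 stand level at the top of these numbers: the step of a number 0.10 log units higher from compound 1 to compound 3 (within the scatter) separates them, while compound 2 lies well under both. The next compound, compound 4 `Cc1ccc2[nH]c(C(=O)N[C@H]3CCN(S(=O)(=O)N(C)C)C[C@@H]3C(=O)NCCN(C)C)cc2c1`, carries dimethylamino in place of piperidin-1-yl on a sulfonyl sulfur and differs in nothing else.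

Within the data shown here, no measured step makes this exact swap, so the closest guides are other changes at the same sulfur. The step of a number 1.30 log units higher from compound 2 to compound 3 (beyond the scatter) came with piperidin-1-yl in place of cyclopropyl, and the step of a number 1.20 log units lower from compound 1 to compound 2 (beyond the scatter) came with cyclopropyl in place of phenyl. Both were large. Dimethylamino is the smaller group in this swap, and compound 2 with its cyclopropyl sits at 1 on this scale, so a clear drop in this assay is expected, a little short of that full difference. The expected step is a number 0.90 log units lower from compound 3 to compound 4 (beyond the scatter) on this estimate. Compound 4 is estimated at 1.4 with an expected range from 1 to 1.8 for the coming measurement.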

Compound 4, distribution coefficient: 1.2
Beside the measured number, compound 4's estimate is 0.20 log units above it, within the range that was stated.
By their numbers in this assay, from the lowest: compounds 2 and 4 (each within the scatter of the next); then compounds 1 and 3 (each within the scatter of the next).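

In this assay, dimethylamino in place of piperidin-1-yl on a sulfonyl sulfur gives a number 1.10 log units lower from compound 3 to compound 4 (beyond the scatter), so having a nitrogen attached to this sulfur does not by itself set the number: the groups attached to that nitrogen matter too. Against the other two compounds, the change gives a number 0.20 log units higher from compound 2 to compound 4 (within the scatter) and a number 1.00 log units lower from compound 1 to compound 4 (beyond the scatter), which places the open-chain dimethylamino group level with the cyclopropyl ring and shows that the presence of a ring does not decide the read-out either. No measured evidence here explains these differences.

The compounds shown do not reveal where a pyrrolidin-1-yl ring or a diethylamino group would fall relative to these two levels. They also leave open what a morpholin-4-yl ring, with an oxygen in the ring, would give.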